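The source may report more compounds than this note shows. Statements on the series, on what has been measured and on what is new or still open speak of the compounds shown alone.

Measured so far:
compound 1 `COC(=O)N1CCCCC1c1ccc(CNc2nccc(C)c2NC(=O)CC#N)cc1`: > 5000 nM
compound 2 `COC(=O)c1ccccc1C1CCC(CNc2nccc(C)c2NC(=O)CC#N)CC1`: 385 nM

In an assay on isolated protein for binding affinity to B1 bradykinin receptor (Homo sapiens) (a higher number here means a weaker inhibitor, a lower number a stronger inhibitor), compound 1 gives > 5000 nM, which is a limit of the assay and not a number; it stands at the limit of > 5000 nM in this assay, at which 1 of the 2 values shown sits. Compound 2 gives 385 nM in this assay. Compound 3 `COC(=O)C1=C(c2ccc(CNc3nccc(C)c3NC(=O)CC#N)cc2)CCC1` carries the change (2-(methoxycarbonyl)cyclopent-1-en-1-yl in place of 1-(methoxycarbonyl)piperidin-2-yl on an aromatic carbon). Within the data shown here, no measured pair covers this change, so its size is open. The step from compound 1 to compound 3 is expected at an at least 3.3-fold lower number from compound 1 to compound 3 (0.52 log units; beyond the scatter), toward stronger binding, an expectation leaning on compound 2 at 385 nM with its methoxycarbonyl on a carbon ring. Compound 3 is estimated at 1500 nM, range 300 nM to 5000 nM.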

Compound 3, inhibition constant: 126 nM
Estimate against measurement, compound 3: 12-fold (1.08 log units) above, outside the stated range (below it).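

In this assay, 2-(methoxycarbonyl)cyclopent-1-en-1-yl in place of 1-(methoxycarbonyl)piperidin-2-yl on the aromatic carbon gives an at least 39-fold lower number from compound 1 to compound 3 (1.59 log units; beyond the scatter). At this position, then, a methoxycarbonyl group on a ring does not by itself settle the read-out; the ring carrying it and the way it is attached also count. Compound 1 stands at a limit of the assay and not at a number, so this step has only a lower bound: the limit of > 5000 nM in this assay, at which 1 of the 3 values shown sits.

The change alters ring size, the ring nitrogen and the double bond together, and the compounds shown do not separate these. Also open, from the compounds shown here alone, is how a carboxylic acid or a primary amide in place of the methoxycarbonyl of compound 3 would read in this assay.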